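The source may hold more compounds than are shown below. What is called first, only, known or untested is meant among the compounds shown, and "the series" means these compounds.

Compound 1 `Cc1ccccc1S(=O)(=O)NCc1ccc(CNC(=O)c2ccc(F)cc2)cc1`: 100 nM
Compound 2 `O=C(NCc1ccc(CNS(=O)(=O)c2cccc3ccccc23)cc1)c1ccc(F)cc1`: 1000 nM
Compound 3 `Cc1cccc(S(=O)(=O)NCc2ccc(CNC(=O)c3ccc(F)cc3)cc2)c1`: 1 nM

All three values come from an assay on MDA-MB-231 cells for binding affinity to C-X-C chemokine receptor type 4 (Homo sapiens), read by fluorescence and microscopy, with stated times of 10 min and 30 min; on this read-out lower numbers stand for an effect already at smaller amounts and higher numbers for an effect only at larger amounts of compound. Compound 3 has the lowest number of the three; the nearest is a 100-fold lower number from compound 1 to compound 3 (2.00 log units; beyond the scatter) and the furthest a 1000-fold lower number from compound 2 to compound 3 (3.00 log units; beyond the scatter). Compound 4 `O=C(NCc1ccc(CNS(=O)(=O)c2cccc(C(F)(F)F)c2)cc1)c1ccc(F)cc1` differs from compound 3 in one place: trifluoromethyl in place of methyl on an aromatic carbon. Among the measured compounds shown here, no measured step exchanges these two groups directly. The measured steps all alter the ring on the sulfonyl sulfur, and a 10-fold higher number from compound 1 to compound 2 (1.00 log units; beyond the scatter) together with a 1000-fold lower number from compound 2 to compound 3 (3.00 log units; beyond the scatter) show that this part of the molecule can move the number strongly. Compound 4 keeps a 3-substituted phenyl like compound 3, so only a moderate step in this assay is expected, estimated as a 5.0-fold higher number from compound 3 to compound 4 (0.70 log units; beyond the scatter). Compound 4 is expected to give about 5 nM, within a range from 1 nM to 30 nM.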

Compound 4, effective concentration (reported as EC, without a stated level of effect): 100 nM
For compound 4 the middle estimate is 20-fold (1.30 log units) below the measured one, outside the stated range (above it).
By their numbers in this assay, from the lowest: compound 3; then compounds 1 and 4 (each within the scatter of the next); then compound 2.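

Even with the ring and its place on that ring unchanged, trifluoromethyl in place of methyl gives a 100-fold higher number from compound 3 to compound 4 (2.00 log units; beyond the scatter), so a single group at this place can matter as much as exchanging the whole ring on the sulfonyl sulfur. The 3-(trifluoromethyl)phenyl ring gives a 10-fold lower number from compound 2 to compound 4 (1.00 log units; beyond the scatter), yet it shows no change at the digits printed from compound 1 to compound 4 (within the scatter), so a 3-substituted phenyl does not by itself secure a low number. Nothing available here explains the size of these steps.

As far as these compounds go, whether other groups at this place, such as an amine, a carboxylic acid or a longer chain, would keep the number low remains open. So does whether the same exchange would have a similar effect on the 2-methylphenyl ring.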